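Macrophage cytotoxicity notes: from compound 1 to compound 4

This account rests on a few compounds, and the source may have more. Where it says the series, first, only, none or still open, it means among the compounds named here.

Measured so far in a toxicity assay on cells (Macrophage, Mus musculus, strain BALB/c) for cytotoxicity, read by MTT assay; on this read-out lower numbers stand for stronger inhibition and higher numbers for weaker inhibition:
- compound 1, `COc1cc(O)cc(O)c1C(=O)/C=C/c1ccc(Cl)cc1`: 19000 nM
- compound 2, `C=CCOc1cc(OC)c(C(=O)/C=C/c2ccccc2Br)c(OCC=C)c1`: 5400 nM
- compound 3, `C=CCOc1cc(OC)c(C(=O)/C=C/c2cc(OC)c(OC)c(OC)c2)c(OCC=C)c1`: 12000 nM

Compound 1 carries the highest number of the three in this assay. Its gap to compound 3 lies within the scatter, so the two cannot be told apart on these numbers. Its gap to compound 2 lies beyond the scatter, compound 2 giving the lower number and hence the stronger inhibition.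

Compound 4, `COc1cc(O)cc(O)c1C(=O)/C=C/c1ccco1`, has not yet been measured in this assay. It differs from compound 1 in one place: furan-2-yl in place of 4-chlorophenyl on a double-bonded chain carbon bound to a double-bonded chain carbon. The shared core of compound 1, with its methoxy group and two hydroxy groups, stays as it is. Among the measured compounds shown here, no measured pair shows a change of this kind, so there is no step to lean on. Compound 4 is expected to give 20000 nM, within 8000 nM to 50000 nM. The step expected from compound 1 to compound 4 is a 1.1-fold higher number from compound 1 to compound 4 (0.02 log units; within the scatter), that is, no change beyond the scatter in either direction.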

Compound 4, half-maximal inhibitory concentration: 384000 nM
Estimate against measurement, compound 4: 19-fold (1.28 log units) below; the whole stated range lies below it.
By their numbers in this assay, from the lowest: compound 2; then compounds 3 and 1 (each within the scatter of the next); then compound 4.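

Position notes: on a double-bonded chain carbon bound to a double-bonded chain carbon, the group is not interchangeable in this assay: furan-2-yl in place of 4-chlorophenyl gives a 20-fold higher number from compound 1 to compound 4 (1.31 log units; beyond the scatter). Among the compounds shown here, the shared core stays the same, so this large step, the first single-place step, belongs to this one exchange, in which higher numbers mean weaker inhibition. No measurement at hand bears on why the number rises so far.

The exchange changes several things at once: the chlorine leaves, the ring goes from six-membered to five-membered, and a ring oxygen enters, so the compounds shown do not separate these contributions. Going by these compounds, a plain phenyl or a thiophen-2-yl at this position on the same core would bear on that question, and whether the step carries over to other cores also remains open.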